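A few compounds are considered here, and "the series" means these few. Any claim that something is new, unique, unknown or untested is made for them only; others in the source may bear on it.

Compound 1 `CS(=O)(=O)c1ccc(C(=O)Nc2ccc(Cl)c(-c3nnc4c(Cl)cccn34)c2)c(Cl)c1` carries a methylsulfonyl group on the benzamide ring of a shared core. In a functional assay on U-251 cells (Homo sapiens) for antiproliferative activity, read by MTT assay, with a stated time of 72 h (on this read-out higher numbers stand for weaker inhibition and lower numbers for stronger inhibition), compound 1 gives 44600 nM. Compound 2 `O=C(Nc1ccc(Cl)c(-c2nnc3c(Cl)cccn23)c1)c1cccc(Cl)c1`, with a chloro group on that ring instead, gives 43100 nM in this assay, and the two numbers sit within the usual scatter of each other. Compound 3 `O=C(Nc1ccc(Cl)c(-c2nnc3c(Cl)cccn23)c1)c1ccccc1Cl` reaches only a limit in this assay, > 100000 nM for compound 3 being the edge of what the test reports rather than a number. Removing the methylsulfonyl group gave an at least 2.2-fold higher number from compound 1 to compound 3 (0.35 log units; beyond the scatter), and moving the chloro group gave an at least 2.3-fold higher number from compound 2 to compound 3 (0.36 log units; beyond the scatter); both steps rest on (the limit of > 100000 nM in this assay, at which 1 of the 3 values shown sits).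

Compound 4 `O=C(Nc1ccc(Cl)c(-c2nnc3c(Cl)cccn23)c1)c1ccc(Cl)cc1Cl` differs from compound 1 by chloro in place of methylsulfonyl on an aromatic carbon. Within the data shown here, no measured pair shows exactly this exchange. The nearest step, from compound 1 to compound 3, weakened inhibition at least modestly when the methylsulfonyl group left, and compound 3 already sits at the limit. For compound 4 a weakening of similar size is therefore expected, with a real chance that the assay again reports only a limit. The expected step is a 1.7-fold higher number from compound 1 to compound 4 (0.23 log units; within the scatter). Compound 4 is estimated at 75000 nM, likely between 30000 nM and 150000 nM.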

Compound 4, half-maximal inhibitory concentration: > 100000 nM
Compound 4: no number, only a limit (the forecaster's own chance of this, stated with the estimate: 45%); middle value at least 1.3-fold (0.12 log units) away from the limit.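

Chloro in place of methylsulfonyl, at the ring position meta to a chloro group and para to a large group, gave an at least 2.2-fold higher number from compound 1 to compound 4 (0.35 log units; beyond the scatter) in this assay, so chloro here does not keep the level of compound 1, just as hydrogen did not. Among these compounds, the 2,4-dichlorophenyl group in place of 3-chlorophenyl on the carbonyl carbon gave an at least 2.3-fold higher number from compound 2 to compound 4 (0.36 log units; beyond the scatter), so adding chloro at this position also fails to hold the level seen with the single chloro group of compound 2. Compound 3 and compound 4 both stand at a limit, so the step between them cannot be read, and the sizes above are only minimum sizes set by that limit: the limit of > 100000 nM in this assay, at which 2 of the 4 values shown sit.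

As far as these compounds go, what an amine or a carboxylic acid at this position would do in this assay remains open, and so does whether any such group could match compound 1 or improve on it. How far compound 3 and compound 4 lie past the limit is also unknown, and with it whether chloro or hydrogen is the better of the two at this position.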